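Adding a Methoxy Group: Expected Effect on Cell Growth

This account rests on a few compounds, and the source may have more. Where it says the series, first, only, none or still open, it means among the compounds named here.

Compound 1 `COc1ccc(-c2cc(/C=C/C(=O)c3ccc(N)cc3)[nH]n2)cc1` and compound 3 `COc1ccc(-c2cc(/C=C/C(=O)c3ccc(N)cc3)[nH]n2)cc1OC` share one core. In a functional assay on OVCAR-4 cells (Homo sapiens) for cytotoxicity, read by sulforhodamine B assay, with a stated time of 48 h, tested at 10 uM (a higher number here means a weaker effect of the compound at the concentration tested, a lower number a stronger effect), compound 1 gives -6%, while compound 3 gives 24%; the step of a number 30 percentage points higher from compound 1 to compound 3 (beyond the scatter) goes with the change (methoxy in place of hydrogen on an aromatic carbon). Compound 2 `COc1ccc(C(=O)/C=C/c2cc(-c3cc(OC)c(OC)c(OC)c3)n[nH]2)cc1OC` is built on a second core, and the difference between the two cores is not broken down here. In this assay compound 2 gives 23%, a number within the scatter of compound 3. Compound 4 `COc1cc(C(=O)/C=C/c2cc(-c3cc(OC)c(OC)c(OC)c3)n[nH]2)cc(OC)c1OC` has not yet been measured; it differs from compound 2 by methoxy in place of hydrogen on an aromatic carbon. This is the same kind of change as before, though here the place is also meta to a methoxy group. Within the data shown here, the expectation rests on the single earlier step of a number 30 percentage points higher from compound 1 to compound 3 (beyond the scatter). Compound 4 is therefore expected to give about 40%, estimated between 15% and 70%, which means an expected step of a number 17 percentage points higher from compound 2 to compound 4 (beyond the scatter).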

Compound 4, a percentage reported as activity, at one concentration (the size of the read-out at that concentration, not a potency): -100%
Beside the measured number, compound 4's estimate is 140 percentage points above it; measured number below the stated range.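

On the core of compound 2, putting methoxy in place of hydrogen on an aromatic carbon goes with a number 123 percentage points lower from compound 2 to compound 4 (beyond the scatter), so in this assay the change does not carry over from one core to the other, even in direction: the same change on two cores in this assay, a number 30 percentage points higher (beyond the scatter) from compound 1 to compound 3 and a number 123 percentage points lower (beyond the scatter) from compound 2 to compound 4, 153 percentage points apart, beyond the scatter of two such steps

This shows that the earlier step cannot be trusted as a guide on the second core. Among these compounds, with only two pairs, it does not show which feature of the cores sets the direction, nor why the two steps differ.

The compounds shown leave open whether an ethoxy group or a fluorine in the same place would behave like the methoxy group of compound 4. They also leave open how other cores in this series would respond to the same change.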